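A few compounds are considered here, and "the series" means these few. Any claim that something is new, unique, unknown or untested is made for them only; others in the source may bear on it.

Values measured in a functional assay on LN-229 cells (Homo sapiens) for antiproliferative activity, with a stated time of 72 h (on this read-out lower numbers stand for stronger inhibition and higher numbers for weaker inhibition), are these:
- compound 1 `Nc1ncnn2c([C@@H]3O[C@H](CO)[C@@H](O)[C@H]3O)cc(C#Cc3ccc(F)cc3)c12` gives > 100000 nM as a limit of the assay
- compound 2 `Nc1ncnn2c([C@@H]3O[C@H](CO)[C@@H](O)[C@H]3O)cc(-c3ccc(F)cc3)c12` gives 65600 nM
- compound 3 `Nc1ncnn2c([C@@H]3O[C@H](CO)[C@@H](O)[C@H]3O)cc(-c3ccoc3)c12` gives 1000 nM

Compound 3 at 1000 nM holds the lowest of the two actual numbers. The third value, that of compound 1, is a limit.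

Compound 4 `Nc1ncnn2c([C@@H]3O[C@H](CO)[C@@H](O)[C@H]3O)cc(/C=C/c3ccccc3)c12` has not been measured yet. It carries 2-phenylethenyl in place of furan-3-yl on an aromatic carbon.

Going by the values given here, two measured steps bear on this change, and both ended on furan-3-yl with a large drop (a 66-fold lower number from compound 2 to compound 3 (1.82 log units; beyond the scatter)) (an at least 100-fold lower number from compound 1 to compound 3 (2.00 log units; beyond the scatter)). The floor of the remaining step (an at least 1.5-fold lower number from compound 1 to compound 2 (0.18 log units; that floor lies within the scatter)) lies within the scatter and tells little.

Compound 4 has a six-membered aromatic ring of carbon only, as do compound 1 and compound 2, so leaving furan-3-yl is expected to raise the number substantially, toward compound 2 with its 65600 nM reading. The expected step is large (a 30-fold higher number from compound 3 to compound 4 (1.48 log units; beyond the scatter)). The estimate for compound 4 in this assay is 30000 nM (expected range 4000 nM to 100000 nM).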

Compound 4, half-maximal inhibitory concentration: 3900 nM
For compound 4 the middle estimate is 7.7-fold (0.89 log units) above the measured one; the measured number lies below the stated range.
By their numbers in this assay, from the lowest: compound 3; then compound 4; then compound 2. At a limit, above all of these: compound 1.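

In this assay, a six-membered aromatic ring of carbon only at this position does not by itself mean weak inhibition, as the change away from furan-3-yl gives only a 3.9-fold higher number from compound 3 to compound 4 (0.59 log units; beyond the scatter). The same kind of ring does far better in 2-phenylethenyl than in 4-fluorophenyl, with a 17-fold lower number from compound 2 to compound 4 (1.23 log units; beyond the scatter), so compound 4 goes against the link between that ring and weak inhibition suggested by compound 1 and compound 2. Compound 1 gives > 100000 nM, a limit of the assay, so an at least 25-fold lower number from compound 1 to compound 4 (1.40 log units; beyond the scatter) is only a floor: the limit of > 100000 nM in this assay, at which 1 of the 4 values shown sits.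

Compound 4 differs from compound 2 in both the double bond and the missing fluorine, and the two cannot be separated here. From the compounds shown here alone, how an amine, a carboxylic acid or a plain propyl chain would read at this position also remains open.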